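A few compounds are considered here, and "the series" means these few. Any claim that something is new, unique, unknown or untested is made for them only; others in the source may bear on it.

In a functional assay on MT2 cells (Homo sapiens) for cytotoxicity, read by MTT assay (a higher number here means that more compound is tolerated, a lower number that less compound is tolerated), compound 1 (`COc1ccc(Nc2nccs2)cc1OCC=C(C)C`) gives 42000 nM and sits at the top of the three measured numbers, level within the scatter with compound 2 (`CC(C)=CCOc1cc(Nc2nccs2)ccc1C(C)C`) at 31000 nM. Compound 3 (`CC(C)=CCOc1cc(Nc2nccs2)ccc1C(=O)O`) gives 17000 nM. Compound 4 (`COc1ccc(Nc2nc(CO)cs2)cc1OCC=C(C)C`) keeps the core of compound 1 and differs in one place, with hydroxymethyl in place of hydrogen on an aromatic carbon.

Among the measured compounds shown here, no measured step touches that place, since all three swap the group that stands where compound 1 carries methoxy. They therefore bear on the question only indirectly, as a guide to how far this series moves. Two of them stay within the scatter, a 1.4-fold lower number from compound 1 to compound 2 (0.13 log units; within the scatter) and a 1.8-fold lower number from compound 2 to compound 3 (0.26 log units; within the scatter). The largest is modest, a 2.5-fold lower number from compound 1 to compound 3 (0.39 log units; beyond the scatter). Given steps of that size, only a small change is expected here, possibly towards less compound tolerated, and most likely none beyond the scatter.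

The expected step is a 1.3-fold lower number from compound 1 to compound 4 (0.10 log units; within the scatter). For compound 4 the estimated value is 33000 nM, with an expected range from 14000 nM to 80000 nM.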

Compound 4, half-maximal cytotoxic concentration: 80000 nM
Compound 4: the middle estimate sits 2.4-fold (0.38 log units) below what was measured, and the stated range covers the measured number.
By their numbers in this assay, from the lowest: compounds 3, 2, 1 and 4 (each within the scatter of the next, the first and the last beyond it).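

Compound 4 is the only compound shown that changes the carbon next to the ring nitrogen on the five-membered aromatic ring, whereas the earlier steps all replace methoxy elsewhere in the molecule. In this assay the swap of hydrogen for hydroxymethyl gives a 1.9-fold higher number from compound 1 to compound 4 (0.28 log units; within the scatter) and so leaves compound 4 level with compound 1, showing that this position can carry this small group without a change beyond the scatter. No measurement here accounts for the size of this step.

As far as these compounds go, it remains open whether an amine or a longer chain at this carbon would shift the number beyond the scatter. From the compounds shown here alone, it is also open whether hydroxymethyl would behave the same way with isopropyl or carboxy in place of methoxy, as in compound 2 and compound 3.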